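Thiophene for phenyl on a nucleoside at the limit

The source may hold more compounds than are shown below. What is called first, only, known or untested is meant among the compounds shown, and "the series" means these compounds.

Compound 1 `Nc1nc2c(c(-c3ccccc3)cn2[C@@H]2O[C@H](CO)[C@@H](O)[C@H]2O)c(=O)[nH]1` is measured in a functional assay on HeLa S3 cells (Homo sapiens) for antiproliferative activity, read by XTT assay, with a stated time of 72 h; on this read-out higher numbers stand for weaker inhibition and lower numbers for stronger inhibition. In this assay compound 1 gives a limit of the assay, > 20000 nM, and so sits at the limit of > 20000 nM in this assay, at which 1 of the 2 values shown sits. Compound 2 `CSc1ncnc2c1c(-c1cccs1)cn2[C@@H]1O[C@H](CO)[C@@H](O)[C@H]1O`, built on a different core, gives 1960 nM in this assay. Compound 3 `Nc1nc2c(c(-c3cccs3)cn2[C@@H]2O[C@H](CO)[C@@H](O)[C@H]2O)c(=O)[nH]1` is not yet measured in this assay. It differs from compound 1 in one place: thiophen-2-yl in place of phenyl on an aromatic carbon. Within the data shown here, with no measured pair showing this change, the step expected from compound 1 to compound 3 is a step that the limit leaves unreadable from compound 1 to compound 3, judged not beyond the scatter, with compound 1 already at the limit. Compound 3 is therefore expected at 30000 nM, between 8000 nM and 100000 nM, most likely reported again only as a limit.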

Compound 3, half-maximal inhibitory concentration: > 20000 nM
Compound 3: no number, only a limit; the forecaster's own chance of this, stated with the estimate: 70%; the middle value does not contradict the limit.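

Compound 1 and compound 3 both stand only as limits, so no step for thiophen-2-yl in place of phenyl can be read: the limit of > 20000 nM in this assay, at which 2 of the 3 values shown sit.

Still open, from the compounds shown here alone, is whether this change on the shared core alters activity in this assay at all.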